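The source may hold more compounds than are shown below. What is called first, only, known or untested is meant among the compounds shown, and "the series" means these compounds.

Measured in a functional assay on ZR-75-1 cells (Homo sapiens) for inhibition, read by sulforhodamine B assay; a lower number here means a stronger inhibitor of growth, a higher number a weaker inhibitor of growth:
- compound 1 `Oc1cccc2[nH]c(-c3ccc(-c4ccc(-c5ccc(OC(F)(F)F)cc5)cc4)cc3)nc12`: 3800 nM
- compound 2 `COc1ccc(-c2ccc(-c3ccc(-c4nc5c(O)cccc5[nH]4)cc3)cc2)cc1`: 8200 nM

Of these two, compound 2 has the higher number, at 8200 nM. Compound 3 `COc1ccc(-c2ccc(-c3ccc(-c4nc5c(O)cccc5[nH]4)cc3)cc2)cc1OC` carries methoxy in place of hydrogen on an aromatic carbon, ortho to a methoxy group: methoxy in place of hydrogen on an aromatic carbon. For the measured compounds named here, the only measured step bearing on this, a 2.2-fold higher number from compound 1 to compound 2 (0.33 log units; beyond the scatter), is modest and exchanges a group on an oxygen, so no measured step adds a group at this carbon. On that limited evidence, the expected result is a 1.1-fold lower number from compound 2 to compound 3 (0.04 log units; within the scatter), with no change beyond the scatter. The estimate for compound 3 is 7500 nM, with an expected range of 3200 nM to 18000 nM.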

Compound 3, concentration for 50% growth inhibition: 2110 nM
The estimate for compound 3 lay 3.6-fold (0.55 log units) above the measured number; the measured number lies below the stated range.
By their numbers in this assay, from the lowest: compounds 3 and 1 (each within the scatter of the next); then compound 2.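

In this assay, methoxy in place of hydrogen on this aromatic carbon, ortho to a methoxy group, gives a 3.9-fold lower number from compound 2 to compound 3 (0.59 log units; beyond the scatter) and so shows that this carbon responds to substitution, which the earlier exchange on oxygen could not show. With 3,4-dimethoxyphenyl in place of 4-(trifluoromethoxy)phenyl, the comparison reads a 1.8-fold lower number from compound 1 to compound 3 (0.26 log units; within the scatter) and leaves these two end groups unseparated. Nothing available here accounts for the effect of the added methoxy.

Still open, as far as these compounds go, is whether the response is specific to methoxy at this carbon or would also appear with a hydroxyl, an amine or a longer chain such as ethoxy.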